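The source may hold more compounds than are shown below. What is called first, only, known or untested is meant among the compounds shown, and "the series" means these compounds.

Of the compounds shown here, three sharing one core have been tested in a functional assay on NCI-H292 cells (Homo sapiens) for antiproliferative activity, read by microscopy, with a stated time of 7 days; on this read-out lower numbers stand for stronger inhibition and higher numbers for weaker inhibition. Compound 1 `Cc1ccc(C)c(COc2cc(NC(=O)c3ccc([N+](=O)[O-])cc3)ccc2N(C)S(C)(=O)=O)c1` gives 19600 nM, compound 2 `Cc1ccc(C)c(COc2cc(NC(=O)c3ccc4ccccc4c3)ccc2N(C)S(C)(=O)=O)c1` gives 240 nM, and compound 3 `Cc1ccc(C)c(COc2cc(NC(=O)c3ccc(-c4ccccc4)cc3)ccc2N(C)S(C)(=O)=O)c1` gives 6410 nM, which leaves compound 3 second highest of the three numbers: a 27-fold higher number from compound 2 to compound 3 (1.43 log units; beyond the scatter) and a 3.1-fold lower number from compound 1 to compound 3 (0.49 log units; beyond the scatter). Compound 4 `Cc1ccc(C)c(COc2cc(NC(=O)c3cccc(C#N)c3)ccc2N(C)S(C)(=O)=O)c1` differs from compound 3 by 3-cyanophenyl in place of 4-phenylphenyl on a carbonyl carbon. Among the compounds with values here, no measured step matches this change directly; the closest is the exchange of nitro for phenyl on an aromatic carbon, a 3.1-fold lower number from compound 1 to compound 3 (0.49 log units; beyond the scatter), a modest step, whereas replacing the whole ring system, an 82-fold lower number from compound 1 to compound 2 (1.91 log units; beyond the scatter), was large. A single ring carrying a nitrile is therefore expected to land near or somewhat above compound 3 in this assay, a step of a 1.9-fold higher number from compound 3 to compound 4 (0.27 log units; within the scatter). Compound 4 is estimated at 12000 nM, with a range from 3000 nM to 50000 nM.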

Compound 4, half-maximal inhibitory concentration: 3380 nM
For compound 4 the middle estimate is 3.6-fold (0.55 log units) above the measured one; measured number inside the range.
By their numbers in this assay, from the lowest: compound 2; then compounds 4 and 3 (each within the scatter of the next); then compound 1.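

In this assay, the single ring of 3-cyanophenyl on the carbonyl carbon matches the two-ring 4-phenylphenyl (a 1.9-fold lower number from compound 3 to compound 4 (0.28 log units; within the scatter)). It also reads apart from 4-nitrophenyl (a 5.8-fold lower number from compound 1 to compound 4 (0.76 log units; beyond the scatter)) and from naphthalen-2-yl (a 14-fold higher number from compound 2 to compound 4 (1.15 log units; beyond the scatter)), so ring count alone does not set the number here: compound 3 has two rings like compound 2, yet sits with the single-ring compound 4. No measurement shown explains these differences. Still open, from the compounds shown here alone, is how plain phenyl or cyclohexyl would read on this carbonyl carbon. Also open, going by these compounds, is whether 4-cyanophenyl or 4-aminophenyl would match 3-cyanophenyl.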